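This account rests on a few compounds, and the source may have more. Where it says the series, first, only, none or still open, it means among the compounds named here.

Of the compounds shown here, three have been tested in a functional assay on MT4 cells (Homo sapiens) for cytotoxicity, read by MTT assay, with a stated time of 5 days; a lower number here means that less compound is tolerated, a higher number that more compound is tolerated. Compound 1, `Cc1cc(-c2ccc(C#N)cc2)c(Cl)cc1Oc1ccnc(Nc2ccc(C#N)cc2)n1`, reaches only a limit of the assay: in this assay compound 1 gives > 285000 nM. That limit is the limit of > 285000 nM in this assay, at which 1 of the 3 values shown sits. Compound 2, `N#Cc1ccc(Nc2nccc(Oc3ccc(-c4ccc(C#N)cc4)c(C(F)(F)F)c3)n2)cc1`, likewise stops at a limit, and in this assay compound 2 gives > 273000 nM. Its limit is the limit of > 273000 nM in this assay, at which 1 of the 3 values shown sits. Compound 3, `Cc1cc(-c2ccc(C#N)cc2)ccc1Nc1ccnc(Nc2ccc(C#N)cc2)n1`, is the only one of the three with an actual number: in this assay compound 3 gives 9200 nM. Compound 3 therefore stands alone among the numbers shown, while the other two entries are limits rather than measured points.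

The compound not yet measured is compound 4, `COc1cc(-c2ccc(C#N)cc2)ccc1Nc1ccnc(Nc2ccc(C#N)cc2)n1`. It differs from compound 3 in one place: methoxy in place of methyl on an aromatic carbon. Among the compounds with values here, no pair of measured compounds shows this same change, so there is no measured step to lean on. For a change of this small size, the step in this assay is expected to stay within the usual scatter, with no clear direction up or down. The estimate for compound 4 in this assay is 10000 nM, expected to lie between 3500 nM and 30000 nM, which amounts to an expected step of a 1.1-fold higher number from compound 3 to compound 4 (0.04 log units; within the scatter).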

Compound 4, half-maximal cytotoxic concentration: > 298000 nM
Compound 4: no number, only a limit; the forecaster's own chance of this, stated with the estimate: 15%; middle value at least 29-fold (1.47 log units) away from the limit.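

Compounds 3 and 4 are the first pair shown that differ in only one place, so this is the first direct reading of what a single group does at this position. In this assay, putting methoxy in place of methyl on this aromatic carbon, ortho to a large group and meta to a 4-cyanophenyl group, gives an at least 32-fold higher number from compound 3 to compound 4 (1.51 log units; beyond the scatter), which means that far more compound is tolerated. The position is therefore not indifferent to this small exchange, although the true size of the step stays unknown because compound 4 reaches only a limit of the assay: the limit of > 298000 nM in this assay, at which 1 of the 4 values shown sits.

The compounds shown leave open whether the oxygen atom itself or simply the larger group accounts for this step, and the reason for it cannot be read from this single pair. They also leave open how an amine, a hydroxyl or a longer chain such as ethoxy on the same carbon would behave, and whether methoxy would give the same step on another core.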